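The source may report more compounds than this note shows. Statements on the series, on what has been measured and on what is new or still open speak of the compounds shown alone.

Values measured in a functional assay on HeLa cells (Homo sapiens) for cytotoxicity, read by MTT assay, with a stated time of 72 h; a lower number here means a stronger inhibitor, a higher number a weaker inhibitor:

- Compound 1 `Cn1ccc2c(Oc3ccc(NC(=O)c4cc5cccnc5n(-c5ccccc5)c4=O)cc3F)ncnc21`: 51800 nM
- Compound 2 `Cn1ccc2c(Oc3ccc(NC(=O)c4cc5cccnc5n(-c5ccc(Cl)cc5)c4=O)cc3F)ncnc21`: 43900 nM
- Compound 3 `Cn1ccc2c(Oc3ccc(NC(=O)c4cc5cccnc5n(-c5ccc(C(F)(F)F)cc5Cl)c4=O)cc3F)ncnc21`: 170000 nM

Compound 1 sits close to compound 2 and well short of compound 3. The numbers show a 1.2-fold lower number from compound 1 to compound 2 (0.07 log units; within the scatter), and also a 3.3-fold higher number from compound 1 to compound 3 (0.52 log units; beyond the scatter).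

The unmeasured compound 4 `O=C(Nc1ccc(Oc2ncnc3[nH]ccc23)c(F)c1)c1cc2cccnc2n(-c2ccccc2)c1=O` keeps the rest of compound 1 and changes one group: hydrogen in place of methyl on an aromatic nitrogen. In words, it has hydrogen in place of methyl on an aromatic nitrogen of a five-membered aromatic ring with 1 nitrogen, part of a fused or bridged system of two rings.

Going by the values given here, no measured step touches this methyl, so the data offer only indirect guidance. All three steps change a different part of the molecule. Chloro in place of hydrogen gave a 1.2-fold lower number from compound 1 to compound 2 (0.07 log units; within the scatter), while the change to the 2-chloro-4-(trifluoromethyl)phenyl group gave a 3.3-fold higher number from compound 1 to compound 3 (0.52 log units; beyond the scatter) and a 3.9-fold higher number from compound 2 to compound 3 (0.59 log units; beyond the scatter). Even these replacements moved the number only modestly, so a large shift is not expected here, though the range must stay wide because this site is untested.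

The expected change in this assay is a 1.3-fold lower number from compound 1 to compound 4 (0.11 log units; within the scatter), which means no step beyond the scatter. For compound 4 the estimated value is 40000 nM, with an expected range from 12000 nM to 100000 nM.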

Compound 4, half-maximal inhibitory concentration: 36900 nM
For compound 4 the middle estimate is 1.1-fold (0.04 log units) above the measured one; low and high end bracket the measured number.
By their numbers in this assay, from the lowest: compounds 4, 2 and 1 (each within the scatter of the next); then compound 3.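

In this assay, going by these compounds alone, hydrogen in place of methyl on the aromatic nitrogen of the five-membered ring gives a 1.4-fold lower number from compound 1 to compound 4 (0.15 log units; within the scatter), the first reading at this position, since the earlier steps all changed the group on the other aromatic nitrogen. The printed step places this change within the scatter, so the assay cannot tell compound 4 from compound 1, and the methyl, a single carbon, can be removed without a shift that this read-out can resolve. No measurement available here explains this outcome or shows what the nitrogen does in these cells.

Hydrogen and methyl are the only groups shown on this nitrogen, so it remains open whether an ethyl group, a longer chain or a chain ending in an amine would also leave the number in place or would move it beyond the scatter. Going by these compounds, it also remains open whether the 2-chloro-4-(trifluoromethyl)phenyl group, which gave a 3.3-fold higher number from compound 1 to compound 3 (0.52 log units; beyond the scatter), would have the same effect in a compound that carries hydrogen on this nitrogen.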